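This account rests on a few compounds, and the source may have more. Where it says the series, first, only, none or still open, it means among the compounds named here.

Compound 1 `Cc1cc2c(cc1Cc1ccc(C(=O)NC[C@H]3CC[C@H](C(N)=O)CC3)o1)C(C)(C)CCC2(C)C` — 13 nM
Compound 2 `Cc1cc2c(cc1Cc1ccc(C(=O)NCc3ccccc3)o1)C(C)(C)CCC2(C)C` — 102 nM
Compound 3 `Cc1cc2c(cc1Cc1ccc(C(=O)NCC3CCC(CN)CC3)o1)C(C)(C)CCC2(C)C` — 42 nM

In an assay on isolated protein for binding affinity to Gonadotropin-releasing hormone receptor (Homo sapiens) (on this read-out higher numbers stand for weaker inhibition and lower numbers for stronger inhibition), compound 3 stands second highest of the three numbers. Its nearest neighbour is set by a 2.4-fold lower number from compound 2 to compound 3 (0.39 log units; beyond the scatter) and its furthest by a 3.2-fold higher number from compound 1 to compound 3 (0.51 log units; beyond the scatter), both modest shifts. Compound 4 `Cc1cc2c(cc1Cc1ccc(C(=O)NCC3CCC(CNCc4cc(O)nc(O)n4)CC3)o1)C(C)(C)CCC2(C)C` differs from compound 3 by (2,6-dihydroxypyrimidin-4-yl)methyl in place of hydrogen on an amine nitrogen. Among the measured compounds shown here, no measured pair alters this amine nitrogen itself; the steps that bear on it, a 3.2-fold higher number from compound 1 to compound 3 (0.51 log units; beyond the scatter) and a 2.4-fold lower number from compound 2 to compound 3 (0.39 log units; beyond the scatter), show only that changing the group on this chain carbon moves this assay modestly, and compound 1 shows the lowest number of the set. A modest lowering is therefore expected for compound 4, a 1.7-fold lower number from compound 3 to compound 4 (0.23 log units; within the scatter). Compound 4 is estimated at 25 nM, with a range from 8 nM to 80 nM.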

Compound 4, inhibition constant: 24 nM
Compound 4: middle estimate off by 1.0-fold (0.02 log units), on the high side; the measured number falls inside the stated range.
By their numbers in this assay, from the lowest: compounds 1, 4 and 3 (each within the scatter of the next, the first and the last beyond it); then compound 2.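

In this assay, placing (2,6-dihydroxypyrimidin-4-yl)methyl on the amine nitrogen leaves the number within the scatter (a 1.8-fold lower number from compound 3 to compound 4 (0.24 log units; within the scatter)). The earlier compounds shown here changed only the group on the saturated chain carbon, whereas this pair shows that a substituent of 9 heavy atoms can sit on this nitrogen with no step the assay can separate from scatter. Nothing measured here explains this outcome. The compounds shown leave open whether the two hydroxy groups or the ring nitrogens of the pyrimidine contribute to this result, as a plain benzyl group on the same nitrogen would test. They also leave open how a methyl group or an acetyl group at this nitrogen would read.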